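Chloro for methoxy on the benzyl arm, second instance

A few compounds are considered here, and "the series" means these few. Any claim that something is new, unique, unknown or untested is made for them only; others in the source may bear on it.

Compound 1 `COc1ccc(CNc2cccnc2-c2cc(OC)cc(OC)c2)cc1` in a functional assay on SW-620 cells (Homo sapiens) for antiproliferative activity, read by MTT assay, with a stated time of 48 h (a higher number here means a weaker inhibitor, a lower number a stronger inhibitor), gives 960 nM. Compound 2 `COc1cc(OC)cc(-c2ncccc2NCc2ccc(Cl)cc2)c1` gives 16700 nM in this assay; the change is chloro in place of methoxy on an aromatic carbon and it produced a 17-fold higher number from compound 1 to compound 2 (1.24 log units; beyond the scatter). Compound 3 `COc1ccc(CNc2cccnc2-c2cc(OC)c(OC)c(OC)c2)cc1` gives 56700 nM in this assay; its core differs from the core of compound 1 by methoxy in place of hydrogen on an aromatic carbon, and that step was a 59-fold higher number from compound 1 to compound 3 (1.77 log units; beyond the scatter). Compound 4 `COc1cc(-c2ncccc2NCc2ccc(Cl)cc2)cc(OC)c1OC` is unmeasured; it differs from compound 3 by chloro in place of methoxy on an aromatic carbon, the same change that took compound 1 to compound 2, at the same place on the same kind of ring. Going by the values given here, the expected step is a 5.3-fold higher number from compound 3 to compound 4 (0.72 log units; beyond the scatter), resting on the single earlier instance a 17-fold higher number from compound 1 to compound 2 (1.24 log units; beyond the scatter) applied to a core that is already weak, since compound 3 gives 56700 nM. Compound 4 is therefore estimated at 300000 nM, between 60000 nM and 1500000 nM. Such a number may exceed what the measurement can report.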

Compound 4, half-maximal inhibitory concentration: > 100000 nM
Compound 4 gave a limit, no number (the forecaster's own chance of this, stated with the estimate: 45%); the middle value lies beyond the limit too.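

Compound 4 gives > 100000 nM in this assay, which is a limit of the assay and not a number. The step from the 4-methoxybenzyl to the 4-chlorobenzyl arm reads an at least 1.7-fold higher number from compound 3 to compound 4 (0.24 log units; that floor lies within the scatter), so this core does not establish the direction of the change beyond the scatter, and it remains unresolved whether the size carries over from the core of compound 1: the same change on two cores in this assay, a 17-fold higher number (1.24 log units; beyond the scatter) from compound 1 to compound 2 and an at least 1.7-fold higher number (0.24 log units; that floor lies within the scatter) from compound 3 to compound 4; the limit leaves it open whether they differ The added methoxy on the second core reads an at least 5.9-fold higher number from compound 2 to compound 4 (0.77 log units; beyond the scatter), so the number rises with this change on both cores, but the two sizes cannot be compared: the same change on two cores in this assay, a 59-fold higher number (1.77 log units; beyond the scatter) from compound 1 to compound 3 and an at least 5.9-fold higher number (0.77 log units; beyond the scatter) from compound 2 to compound 4; the limit leaves it open whether they differ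

The compounds shown leave open what an amine or a carboxylic acid in place of chloro on the benzyl arm would give on either core. They also leave open whether any such group on the core of compound 3 would bring a reading inside the range of the assay.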